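Indoline Sulfonamides: Swapping Fluoropyridyl for Furyl

This account rests on a few compounds, and the source may have more. Where it says the series, first, only, none or still open, it means among the compounds named here.

Compound 1 `COc1ccc(S(=O)(=O)N2CCc3cccc(-c4ccc(F)nc4)c32)cc1`: 135 nM
Compound 2 `COc1ccc(S(=O)(=O)N2CCc3cccc(-c4c(F)c(F)c(F)c(F)c4F)c32)cc1`: 4760 nM
Compound 3 `COc1ccc(S(=O)(=O)n2ccc3cccc(-c4ccc(F)cc4)c32)cc1`: 212 nM

Three compounds sharing a methoxyphenylsulfonyl group on a bicyclic core have been measured in a functional assay on NCI-H460 cells (Homo sapiens) for inhibition, with a stated time of 72 h; on this read-out lower numbers stand for stronger inhibition and higher numbers for weaker inhibition. Compound 1 gives the lowest number of the three, 135 nM. Compound 3 sits close to it at 212 nM, a gap that lies within the scatter of this assay, so no order between compound 1 and compound 3 can be claimed. Compound 2, carrying a pentafluorophenyl group, stands far apart at 4760 nM, a gap beyond the scatter.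

Compound 4 `COc1ccc(S(=O)(=O)N2CCc3cccc(-c4ccco4)c32)cc1` has not yet been measured. Compared with compound 1 the difference is furan-2-yl in place of 6-fluoropyridin-3-yl on an aromatic carbon. Within the data shown here, the data hold no measured pair that shows how a five-membered aromatic ring in this position compares with a six-membered one; the only large change seen so far, in compound 2, is of a different kind.

Compound 4 is therefore expected to fall somewhat weaker than compound 1, with a step from compound 1 to compound 4 of a 2.2-fold higher number from compound 1 to compound 4 (0.35 log units; beyond the scatter) in this assay, though a result within the scatter would not surprise. The estimate for compound 4 is 300 nM, with a range from 100 nM to 900 nM.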

Compound 4, half-maximal inhibitory concentration: 94.5 nM
Beside the measured number, compound 4's estimate is 3.2-fold (0.50 log units) above it; measured number outside the range, below it.
By their numbers in this assay, from the lowest: compounds 4, 1 and 3 (each within the scatter of the next, the first and the last beyond it); then compound 2.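

In this assay the exchange on this aromatic carbon gives a 1.4-fold lower number from compound 1 to compound 4 (0.15 log units; within the scatter) and so sets no order between the two groups. The position thus accepts furan-2-yl, a five-membered aromatic ring with fewer heavy atoms, in place of the six-membered 6-fluoropyridin-3-yl, with no change beyond the scatter, and neither a fluorine nor a ring nitrogen is needed on this group for the number to stay in that range. Nothing measured here accounts for why the two groups give numbers so close together.

The compounds shown leave open whether this tolerance extends to other five-membered rings, such as thiophene, pyrazole or thiazole, to the furan joined through its other carbon as furan-3-yl, or to a furan carrying a further substituent such as an aminomethyl group or a carboxylic acid. They also leave open whether furan-2-yl would behave in the same way on the core of compound 3, and whether a non-aromatic ring such as morpholine would be accepted on this carbon at all.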